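Chloro Added to a Core That Sits at the Limit

The source may report more compounds than this note shows. Statements on the series, on what has been measured and on what is new or still open speak of the compounds shown alone.

Compound 2 `N#CC1=C(N)Oc2cc3oc(-c4ccccc4)cc(=O)c3c(O)c2C12C(=O)Nc1ccccc12` stands at a limit of the assay: in a functional assay on NCI-H1299 cells (Homo sapiens) for antiproliferative activity, read by MTT assay, with a stated time of 48 h (on this read-out higher numbers stand for weaker inhibition and lower numbers for stronger inhibition), compound 2 gives > 50000 nM. Compound 1 `CN1C(=O)C2(C(C#N)=C(N)Oc3cc4oc(-c5ccccc5)cc(=O)c4c(O)c32)c2cccc(Cl)c21` also stands at a limit, as in this assay compound 1 gives > 50000 nM. Going by the values given here, both values rest at the limit of > 50000 nM in this assay, at which 2 of the 2 values shown sit, so no measured step has a size. Compound 3 `N#CC1=C(N)Oc2cc3oc(-c4ccccc4)cc(=O)c3c(O)c2C12C(=O)Nc1c(Cl)cccc12` carries chloro in place of hydrogen on an aromatic carbon. No step beyond the scatter is expected from this change, and a limit is again the likeliest outcome. Compound 3 is therefore estimated at 60000 nM (range 15000 nM to 200000 nM). The expected step is a step that the limit leaves unreadable from compound 2 to compound 3.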

Compound 3, half-maximal inhibitory concentration: > 50000 nM
Compound 3: no number, only a limit; the forecaster's own chance of this, stated with the estimate: 85%; the middle value does not contradict the limit.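

In this assay the steps from compound 1 and compound 2 to compound 3 cannot be read, as all three values are limits: the limit of > 50000 nM in this assay, at which 3 of the 3 values shown sit. The compounds shown leave open which change to the shared core would give a measurable value.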